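Aryl ketone variation on the shared core: compound 4

A few compounds are considered here, and "the series" means these few. Any claim that something is new, unique, unknown or untested is made for them only; others in the source may bear on it.

Measured in a functional assay on A549 cells (Homo sapiens) for cytotoxicity, read by MTT assay, with a stated time of 48 h; on this read-out higher numbers stand for weaker inhibition and lower numbers for stronger inhibition:
- compound 1 `COc1cc(C(=O)C2Sc3nnc(-c4cc(OC)c(OC)c(OC)c4)n3NC2c2ccco2)cc(OC)c1OC`: 48300 nM
- compound 2 `COc1cc(-c2nnc3n2NC(c2ccco2)C(C(=O)c2ccccc2F)S3)cc(OC)c1OC`: 78700 nM
- compound 3 `COc1cc(-c2nnc3n2NC(c2ccco2)C(C(=O)c2ccc(F)cc2)S3)cc(OC)c1OC`: 53700 nM

Compound 3 holds the second highest of the three numbers. Its nearest neighbour is compound 1, with a 1.1-fold higher number from compound 1 to compound 3 (0.05 log units; within the scatter); the widest gap is to compound 2, with a 1.5-fold lower number from compound 2 to compound 3 (0.17 log units; within the scatter). Both steps sit within the scatter, so the three measured compounds are not separated on this read-out.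

Compound 4 `COc1cc(-c2nnc3n2NC(c2ccco2)C(C(=O)c2cccc4ccccc24)S3)cc(OC)c1OC` is not yet measured. It differs from compound 3 in one place: naphthalen-1-yl in place of 4-fluorophenyl on a carbonyl carbon. The measured steps that bear on this place are all exchanges of the aryl group on the same carbonyl carbon: a 1.6-fold higher number from compound 1 to compound 2 (0.21 log units; within the scatter), a 1.1-fold higher number from compound 1 to compound 3 (0.05 log units; within the scatter) and a 1.5-fold lower number from compound 2 to compound 3 (0.17 log units; within the scatter). None of them leaves the scatter, so the aryl group on this carbonyl carbon has not so far moved the number. Among the compounds with values here, no measured compound carries a naphthalen-1-yl or any second fused ring at this position, so the data give no direct read on that group.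

Compound 4 is therefore expected to stay close to compound 3, with a 1.0-fold higher number from compound 3 to compound 4 (0.01 log units; within the scatter), a step not beyond the scatter. The estimated value for compound 4 is 55000 nM, with a range of 25000 nM to 120000 nM.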

Compound 4, half-maximal inhibitory concentration: > 100000 nM
Compound 4: no number, only a limit; the forecaster's own chance of this, stated with the estimate: 10%; at least 1.8-fold (0.25 log units) between middle value and limit.
By their numbers in this assay, from the lowest: compounds 1, 3 and 2 (each within the scatter of the next). At a limit, above all of these: compound 4.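

In this assay the reading for compound 4 is a limit of the assay and not a number: the limit of > 100000 nM in this assay, at which 1 of the 4 values shown sits.

Of the aryl exchanges shown on this carbonyl carbon, only the one to naphthalen-1-yl gives a step beyond the scatter, with an at least 2.0-fold higher number from compound 1 to compound 4 (0.31 log units; beyond the scatter). Against the two fluorophenyl compounds the floors stay within the scatter, with an at least 1.8-fold higher number from compound 3 to compound 4 (0.27 log units; that floor lies within the scatter) and an at least 1.2-fold higher number from compound 2 to compound 4 (0.10 log units; that floor lies within the scatter), so the change is resolved only against 3,4,5-trimethoxyphenyl, and the size of these two steps remains unsettled.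

The compounds shown leave open how far compound 4 actually lies from the other three, and whether the step belongs to the second aromatic ring as such or to this particular naphthalen-1-yl attachment. A naphthalen-2-yl or an unsubstituted phenyl on the same carbonyl carbon would help to separate these two readings, while a pyridin-3-yl or a cyclohexyl would show whether any group other than a carbon-only aromatic ring is tolerated here.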